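Swapping 3-fluorophenyl for 4-methylphenyl on a sulfur

This account rests on a few compounds, and the source may have more. Where it says the series, first, only, none or still open, it means among the compounds named here.

Compound 1 `COc1ccc(SCc2ccc(C(=O)Nc3ccccc3N)cc2)cc1` gives 70.7%
Compound 2 `Nc1ccccc1NC(=O)c1ccc(CSc2cccc(F)c2)cc1` gives 72.7%

In a functional assay on A549 cells (Homo sapiens) for inhibition, read by CCK-8 assay, with a stated time of 72 h, tested at 8 uM (a higher number here means more inhibition of growth at the concentration tested, a lower number less inhibition of growth), compound 1 and compound 2 (72.7%) stand level, within the usual scatter. Compound 3 `Cc1ccc(SCc2ccc(C(=O)Nc3ccccc3N)cc2)cc1` has 4-methylphenyl in place of 3-fluorophenyl on a sulfur. Going by the values given here, only one measured step changes the group on that sulfur, and it is small: a number 2 percentage points higher from compound 1 to compound 2 (within the scatter) is all it shows. On that evidence no step beyond the scatter is expected in this assay, and the estimated step is small (a number 2.7 percentage points lower from compound 2 to compound 3 (within the scatter)). The expected value for compound 3 is 70% (estimated range 60% to 79%).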

Compound 3, percent growth inhibition at one concentration: 78.3%
Estimate against measurement, compound 3: 8.3 percentage points below; low and high end bracket the measured number.
By their numbers in this assay, from the lowest: compounds 1, 2 and 3 (each within the scatter of the next).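

In this assay, two more changes to the group on the sulfur stay within the scatter: a number 5.6 percentage points higher from compound 2 to compound 3 (within the scatter), and a number 7.6 percentage points higher from compound 1 to compound 3 (within the scatter). The 3-fluorophenyl, 4-methoxyphenyl and 4-methylphenyl groups therefore stand level here, so these three compounds do not separate on this position. Nothing measured here explains why they read alike.

Still open, as far as these compounds go, is whether a phenyl ring carrying an amine or a carboxylic acid, or a plain alkyl chain on the sulfur in place of the ring, would move the number beyond the scatter.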